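Methoxy added to the carbonyl-side aryl ring

A few compounds are considered here, and "the series" means these few. Any claim that something is new, unique, unknown or untested is made for them only; others in the source may bear on it.

Among the compounds with values here, compound 2 `COc1ccc(C(=O)/C=C/c2cc(-c3cc(OC)c(OC)c(OC)c3)n[nH]2)cc1` gives 3850 nM in a functional assay on Malme-3M cells (Homo sapiens) for inhibition, read by sulforhodamine B assay, with a stated time of 48 h (a lower number here means a stronger inhibitor of growth, a higher number a weaker inhibitor of growth), and is the only plain number in the set. Compound 1 `COc1cc(-c2cc(/C=C/C(=O)c3ccc(Cl)c(Cl)c3)[nH]n2)cc(OC)c1OC` returns only a limit, > 100000 nM, in this assay (the limit of > 100000 nM in this assay, at which 1 of the 2 values shown sits). Within the data shown here, the single measured step, an at least 25-fold lower number from compound 1 to compound 2 (1.41 log units; beyond the scatter), replaced the aryl on the carbonyl carbon and was large. Compound 3 `COc1ccc(C(=O)/C=C/c2cc(-c3cc(OC)c(OC)c(OC)c3)n[nH]2)cc1OC` differs from compound 2 by methoxy in place of hydrogen on an aromatic carbon, read one bond further out as 4-methoxyphenyl to 3,4-dimethoxyphenyl, on that same ring. That step shows the ring matters but gives no direction for an added methoxy. The step expected is a 1.3-fold lower number from compound 2 to compound 3 (0.11 log units; within the scatter), within the scatter. Compound 3 is estimated at 3000 nM, between 900 nM and 10000 nM.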

Compound 3, concentration for total growth inhibition: 3680 nM
Compound 3: middle estimate off by 1.2-fold (0.09 log units), on the low side; low and high end bracket the measured number.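

In this assay, the added methoxy gives no change that can be told apart from the scatter: a 1.0-fold lower number from compound 2 to compound 3 (0.02 log units; within the scatter). The move from 4-methoxyphenyl to 3,4-dimethoxyphenyl is therefore tolerated on this ring, and the large difference from the 3,4-dichlorophenyl ring holds with the second methoxy present: an at least 27-fold lower number from compound 1 to compound 3 (1.43 log units; beyond the scatter). That step is a bound rather than a size, since compound 1 gives only a limit: the limit of > 100000 nM in this assay, at which 1 of the 3 values shown sits.

Open, as far as these compounds go, is whether a hydroxyl or an amine on this ring in place of methoxy would move the number beyond the scatter. Also open, from the compounds shown here alone, is what a single chlorine on this ring would give.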